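The source may report more compounds than this note shows. Statements on the series, on what has been measured and on what is new or still open speak of the compounds shown alone.

Measured in a functional assay on A-431 cells (Homo sapiens) for antiproliferative activity, read by sulforhodamine B assay, with a stated time of 72 h; on this read-out higher numbers stand for weaker inhibition and lower numbers for stronger inhibition:
compound 1 `COCCCNC(=O)Nc1cc2c(Nc3ccc(F)c(Cl)c3)ncnc2cc1O[C@H]1CCOC1`, 4100 nM
compound 2 `CCN(CC)CCN(C)C(=O)Nc1cc2c(Nc3ccc(F)c(Cl)c3)ncnc2cc1O[C@H]1CCOC1`, 481 nM

Within the data shown here, compound 2 holds the lower of the two numbers in this assay; its only neighbour is compound 1, reached through an 8.5-fold lower number from compound 1 to compound 2 (0.93 log units; beyond the scatter), a step beyond the scatter. Compound 3 `CN(C)CCCN(C)C(=O)Nc1cc2c(Nc3ccc(F)c(Cl)c3)ncnc2cc1O[C@H]1CCOC1` differs from compound 2 by (dimethylamino)methyl in place of diethylamino on a saturated chain carbon, two bonds along the chain from an amide-type nitrogen. No measured step covers this change: the single step shown exchanges the (3-methoxypropyl)amino group for the (2-(diethylamino)ethyl)(methyl)amino group and says nothing about trimming the amine. The step expected in this assay is therefore a 1.1-fold lower number from compound 2 to compound 3 (0.03 log units; within the scatter), nothing beyond the scatter. Compound 3 is estimated at 450 nM, within 150 nM to 1400 nM.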

Compound 3, half-maximal inhibitory concentration: 200 nM
Compound 3: middle estimate off by 2.3-fold (0.35 log units), on the high side, within the range that was stated.
By their numbers in this assay, from the lowest: compound 3; then compound 2; then compound 1.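

In this assay, the amine end of the side chain is not indifferent: the exchange of diethylamino for (dimethylamino)methyl gives a 2.4-fold lower number from compound 2 to compound 3 (0.38 log units; beyond the scatter). Against (3-methoxypropyl)amino, a second amine-bearing group now also gives a lower number, a 21-fold lower number from compound 1 to compound 3 (1.31 log units; beyond the scatter), and neither amine-bearing compound goes against this. Nothing available explains either step.

This change alters chain length and the groups on the nitrogen together, and their contributions cannot be separated here. A 3-(diethylamino)propyl or 2-(dimethylamino)ethyl group on the same methylated nitrogen would separate them.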